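Methoxy added to the phenyl of the hydroxy(phenyl)methyl series

The compounds below may be only part of what the source reports. "The series", "measured", "known", "first", "only" and "open" are said of these compounds alone.

Of the compounds shown here, three have been tested in a functional assay on RAW264.7 cells (Mus musculus) for inhibition, with stated times of 2 h and 24 h; a lower number here means a stronger inhibitor, a higher number a weaker inhibitor. Compound 1 `COc1cc(OC)cc([C@@H]2C(SCc3ccccc3)c3cc(OC)cc(OC)c3[C@H]2c2ccccc2)c1` reaches only the limit of this assay, > 200000 nM. Compound 2 `COc1ccc(CSC2c3cc(OC)cc(OC)c3[C@@H](c3ccccc3)[C@@H]2c2cc(OC)cc(OC)c2)cc1` likewise sits at the limit, > 200000 nM. The two differ by methoxy in place of hydrogen on an aromatic carbon, and the step that the two limits leave unreadable from compound 1 to compound 2 cannot be sized because of the limit of > 200000 nM in this assay, at which 2 of the 3 values shown sit. Within the data shown here, compound 3 `COc1cc(OC)cc([C@@H]2C(C(O)c3ccccc3)c3cc(OC)cc(OC)c3[C@H]2c2ccccc2)c1` gives 21600 nM, the only real number so far; it is reached by an at least 9.2-fold lower number from compound 1 to compound 3 (0.96 log units; beyond the scatter) and by an at least 9.2-fold lower number from compound 2 to compound 3 (0.96 log units; beyond the scatter), the change being (hydroxy(phenyl)methyl in place of benzylsulfanyl on a saturated ring carbon).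

Compound 4 `COc1ccc([C@@H]2c3c(OC)cc(OC)cc3C(C(O)c3ccccc3)[C@H]2c2cc(OC)cc(OC)c2)cc1` is not yet measured. Relative to compound 3 it carries methoxy in place of hydrogen on an aromatic carbon, the same change as that from compound 1 to compound 2, while the cores of the two pairs differ by hydroxy(phenyl)methyl in place of benzylsulfanyl on a saturated ring carbon. Among the measured compounds shown here, the only earlier instance of this change gives no readable size, so the expectation for compound 4 rests on compound 3 alone, and the step is expected to be small, a 1.1-fold lower number from compound 3 to compound 4 (0.03 log units; within the scatter). Compound 4 is therefore estimated at 20000 nM, with a likely span from 7000 nM to 60000 nM.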

Compound 4, half-maximal inhibitory concentration: > 200000 nM
Compound 4 was reported as a limit; the forecaster's own chance of this, stated with the estimate: 10%; middle value at least 10-fold (1.00 log units) from the limit.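

On the core of compound 3, the change from phenyl to 4-methoxyphenyl in this assay gives an at least 9.2-fold higher number from compound 3 to compound 4 (0.96 log units; beyond the scatter), so on this core the change does not leave the value intact. From the compounds shown here alone, compound 4 is reported only as a limit of the assay, > 200000 nM, and the true size of the step stays unknown beyond what is printed. This does not show that the change carries over from one core to another, since the methoxy sits on the benzyl group in compound 2 but on the phenyl carried by the core in compound 4, and the step from compound 1 to compound 2 cannot be read because both ends stand at the limit: the limit of > 200000 nM in this assay, at which 3 of the 4 values shown sit.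

Open, going by these compounds, is whether the drop belongs to methoxy itself or would also follow hydroxy, an amine or a carboxylic acid at the same place. Also open, on these data alone, is whether methoxy on the phenyl of the hydroxy(phenyl)methyl group would keep the value of compound 3, 21600 nM.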